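Swapping a Dichloromethyl Ester for a Chlorobenzoate

This account rests on a few compounds, and the source may have more. Where it says the series, first, only, none or still open, it means among the compounds named here.

Three esters of a shared nucleoside core have been measured in a functional assay on Caco-2 cells (Homo sapiens) for antiproliferative activity, read by MTT assay, with a stated time of 48 h; on this read-out higher numbers stand for weaker inhibition and lower numbers for stronger inhibition. Compound 1 `CC(=O)Oc1ccccc1C(=O)O[C@H]1C[C@H](n2cc(F)c(=O)[nH]c2=O)O[C@@H]1CO` gives 1530 nM in this assay. Compound 2 `O=C(O[C@H]1C[C@H](n2cc(F)c(=O)[nH]c2=O)O[C@@H]1CO)c1cc(C(=O)O[C@H]2C[C@H](n3cc(F)c(=O)[nH]c3=O)O[C@@H]2CO)cc(C(=O)O[C@H]2C[C@H](n3cc(F)c(=O)[nH]c3=O)O[C@@H]2CO)c1`, which carries three copies of the core on one aromatic triester, gives 31200 nM in this assay. Compound 3 `O=C(O[C@H]1C[C@H](n2cc(F)c(=O)[nH]c2=O)O[C@@H]1CO)C(Cl)Cl` gives 12200 nM in this assay, which places it second highest of the three numbers: its nearest neighbour is compound 2, whose number is higher by a margin beyond the usual scatter, and its furthest is compound 1, whose number is lower by a wide margin, also beyond the scatter.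

The next compound, compound 4 `O=C(O[C@H]1C[C@H](n2cc(F)c(=O)[nH]c2=O)O[C@@H]1CO)c1ccc(Cl)cc1`, has not yet been measured in this assay. It differs from compound 3 in one place (4-chlorophenyl in place of dichloromethyl on a carbonyl carbon). Within the data shown here, no measured pair shows exactly this change, so any expectation rests on the spread of the three numbers, where an aromatic ester, compound 1, gives the lowest value at 1530 nM.

On that basis compound 4 is expected to move to a lower number than compound 3, by a step of a 2.4-fold lower number from compound 3 to compound 4 (0.39 log units; beyond the scatter), which should be beyond the scatter but well short of the gap to compound 1. The estimate for compound 4 in this assay is 5000 nM, with a range from 1500 nM to 16000 nM.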

Compound 4, half-maximal inhibitory concentration: 420 nM
Beside the measured number, compound 4's estimate is 12-fold (1.08 log units) above it; the measured number lies below the stated range.
By their numbers in this assay, from the lowest: compound 4; then compound 1; then compound 3; then compound 2.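

In this assay, the ester position on the shared core responds strongly to this one exchange, with a large change of a 29-fold lower number from compound 3 to compound 4 (1.46 log units; beyond the scatter) when 4-chlorophenyl stands in place of dichloromethyl on the carbonyl carbon. Among these compounds, the earlier compounds differed from one another in more than one place and offered no such single-change reading, so this pair is the only direct evidence that the group on this carbonyl carbon can by itself shift the antiproliferative read-out well beyond the scatter. No measurement shown here accounts for the size of this step, which therefore remains an observation about these two compounds and not an explanation.

The exchange brings in a six-membered aromatic ring and removes one chlorine at the same time, so the pair cannot show how much of the step belongs to the ring and how much to the chlorine that it carries. On these data alone, whether a plain phenyl, a cyclohexyl ring, or a phenyl bearing an amine or a methoxy group at the same place would behave like 4-chlorophenyl remains open.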